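The source may hold more compounds than are shown below. What is called first, only, known or untested is meant among the compounds shown, and "the series" means these compounds.

Compound 1 `CCCCCCCCCCCCC(C)OC(=O)NC(=O)Nc1c(C(C)C)cccc1C(C)C`: in an assay on microsomes from intestine for inhibition of acyl-CoA:cholesterol acyltransferase (Oryctolagus cuniculus) (on this read-out higher numbers stand for weaker inhibition and lower numbers for stronger inhibition), compound 1 gives 46 nM.
Compound 2 `CC(C)c1cccc(C(C)C)c1OC(=O)NC(=O)N(c1ccccc1)c1ccccc1`: in this assay compound 2 gives 170 nM.
Compound 3 `CC(C)c1cccc(C(C)C)c1OC(=O)NC(=O)OCCCc1ccccc1`: in this assay compound 3 gives 660 nM.

Among these three numbers compound 3 stands highest, so it is the weakest inhibitor of the set. Compound 2 is nearest to it, and compound 1 is furthest away with the lowest number; both gaps lie beyond the scatter of repeated measurements.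

Compound 4 `CCCCCCCCCCCCOC(=O)NC(=O)Oc1c(C(C)C)cccc1C(C)C` differs from compound 3 in one place: nonyl in place of phenyl on a saturated chain carbon, three bonds along the chain from an oxygen next to a carbonyl group. The carbamate chain thus loses its ring end and becomes a plain, longer saturated chain. Within the data shown here, compound 1 is the only measured compound with a long saturated chain, and its number is the lowest, but it also differs from compound 4 elsewhere, so it is only a loose guide. A step downward, toward stronger inhibition, is expected, of moderate size: the step from compound 3 to compound 4 is estimated at a 4.4-fold lower number from compound 3 to compound 4 (0.64 log units; beyond the scatter). Compound 4 is therefore expected to give about 150 nM, within a range from 40 nM to 600 nM.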

Compound 4, half-maximal inhibitory concentration: 21 nM
Compound 4: middle estimate off by 7.1-fold (0.85 log units), on the high side, outside the stated range (below it).
By their numbers in this assay, from the lowest: compound 4; then compound 1; then compound 2; then compound 3.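

In this assay putting nonyl in place of phenyl at this position gives a 31-fold lower number from compound 3 to compound 4 (1.50 log units; beyond the scatter) and so strengthens inhibition considerably. This position therefore accepts a long saturated chain with no ring at its end, and the ring of compound 3 is not needed for inhibition on this core. Nothing measured here explains why the step is so large.

The compounds shown leave open whether the gain follows chain length alone, since phenyl and nonyl differ both in having a ring and in their number of carbons, and a phenyl group at the end of a longer chain would help separate the two. From the compounds shown here alone, it also remains open whether a shorter chain such as butyl, or a chain ending in an amine or a carboxylic acid, would keep this strength.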